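This account rests on a few compounds, and the source may have more. Where it says the series, first, only, none or still open, it means among the compounds named here.

Measured so far in an assay on isolated protein for inhibition of serine/threonine-protein kinase TNNI3K (Homo sapiens); a lower number here means a stronger inhibitor, a higher number a weaker inhibitor:
compound 1, `O=C(Nc1ccc(Oc2cc(O)ncn2)cc1)Nc1cccc(C(F)(F)F)c1`: 3200 nM
compound 2, `COc1cc(Oc2ccc(NC(=O)Nc3cccc(C(F)(F)F)c3)cc2)ncn1`: 4000 nM

Among the compounds with values here, compound 2 carries the highest of these two numbers, and its nearest neighbour is compound 1; the single measured step, a 1.3-fold higher number from compound 1 to compound 2 (0.10 log units; within the scatter), lies within the scatter, so the two compounds cannot be told apart on potency. Compound 3, `CNc1nccc(Oc2ccc(NC(=O)Nc3cccc(C(F)(F)F)c3)cc2)n1`, differs from compound 2 by 2-(methylamino)pyrimidin-4-yl in place of 6-methoxypyrimidin-4-yl on an oxygen on an aromatic ring. Within the data shown here, the one step on record, a 1.3-fold higher number from compound 1 to compound 2 (0.10 log units; within the scatter), alters only the substituent on the oxygen of that ring, while the change to compound 3 exchanges the ring itself; no measured pair speaks to that exchange. With nothing to indicate a shift in either direction, compound 3 is expected to sit near compound 2, with an expected step of a 1.3-fold lower number from compound 2 to compound 3 (0.12 log units; within the scatter) in this assay . Compound 3 is therefore estimated at 3000 nM, with a range from 800 nM to 12000 nM.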

Compound 3, half-maximal inhibitory concentration: 50 nM
For compound 3 the middle estimate is 60-fold (1.78 log units) above the measured one; the measured number lies below the stated range.
By their numbers in this assay, from the lowest: compound 3; then compounds 1 and 2 (each within the scatter of the next).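

In this assay the group on the oxygen on the aromatic ring proves able to move the number strongly, which the hydroxy-to-methoxy pair could not show: 2-(methylamino)pyrimidin-4-yl in place of 6-methoxypyrimidin-4-yl gives an 80-fold lower number from compound 2 to compound 3 (1.90 log units; beyond the scatter) and, in place of 6-hydroxypyrimidin-4-yl, gives a 64-fold lower number from compound 1 to compound 3 (1.81 log units; beyond the scatter) in the same direction. Compared with the methoxy compound, the entering group swaps an oxygen for a nitrogen and adds a hydrogen-bond donor, with the heavy-atom count unchanged. Nothing available explains the size of these steps.

The compounds shown do not separate the methylamino group itself from its place on the pyrimidine, as both differ at once. Going by these compounds, it also stays open how a plain amine, an ethylamino chain or a dimethylamino group would compare with the methylamino group.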